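Compound 3 to compound 4: swapping one side group

The source may report more compounds than this note shows. Statements on the series, on what has been measured and on what is new or still open speak of the compounds shown alone.

- compound 1 `O=c1[nH]c(=O)n([C@H]2C[C@H](O)[C@@H](CO)O2)cc1[N+](=O)[O-]`: 130 nM
- compound 2 `C=Cc1cn([C@H]2C[C@H](O)[C@@H](CO)O2)c(=O)[nH]c1=O`: 14200 nM
- compound 3 `[N-]=[N+]=NCc1cn([C@H]2C[C@H](O)[C@@H](CO)O2)c(=O)[nH]c1=O`: 124000 nM

In an ADME assay on L1210/0 cells (Mus musculus) for cytotoxicity, with a stated time of 48 h (on this read-out higher numbers stand for weaker inhibition and lower numbers for stronger inhibition), compound 3 gives 124000 nM, the highest of the three numbers and so the weakest inhibition here. The next structure, compound 4 `O=c1[nH]c(=O)n([C@H]2C[C@H](O)[C@@H](CO)O2)cc1C#CCCO`, carries 4-hydroxybut-1-yn-1-yl in place of azidomethyl on an aromatic carbon.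

Going by the values given here, no measured step brings in this new group, so the guidance is indirect. Two steps away from the nitro compound were large: a 110-fold higher number from compound 1 to compound 2 (2.04 log units; beyond the scatter) and a 950-fold higher number from compound 1 to compound 3 (2.98 log units; beyond the scatter). The closest comparison is modest: an 8.7-fold higher number from compound 2 to compound 3 (0.94 log units; beyond the scatter). Neither compound 2 nor compound 3 carries nitro, and compound 4 lacks it too, so compound 4 is expected to stay near these two rather than near compound 1.

In this assay no step beyond the scatter is expected, and the estimated change is a 1.8-fold lower number from compound 3 to compound 4 (0.25 log units; within the scatter). Compound 4 is estimated at 70000 nM, with an expected range from 12000 nM to 300000 nM.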

Compound 4, half-maximal inhibitory concentration: > 200000 nM
Compound 4 gave a limit, no number; the forecaster's own chance of this, stated with the estimate: 25%; at least 2.8-fold (0.45 log units) between middle value and limit.
By their numbers in this assay, from the lowest: compound 1; then compound 2; then compound 3. At a limit, above all of these: compound 4.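

Compound 4 gives a limit rather than a number in this assay: the limit of > 200000 nM in this assay, at which 1 of the 4 values shown sits.

The step of an at least 1.6-fold higher number from compound 3 to compound 4 (0.20 log units; that floor lies within the scatter) therefore sets only a floor, and that floor cannot separate 4-hydroxybut-1-yn-1-yl from azidomethyl on this aromatic carbon. The other two steps are clear, an at least 14-fold higher number from compound 2 to compound 4 (1.14 log units; beyond the scatter) and an at least 1500-fold higher number from compound 1 to compound 4 (3.18 log units; beyond the scatter), so a third replacement for nitro, this time a chain with a triple bond and a hydroxy end, also leaves the number far higher, and among these four compounds nitro alone gives a number this low.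

The compounds shown leave open whether a plain ethynyl group or an amine on the same carbon would bring the number back towards that of compound 1. As far as these compounds go, whether the triple bond or the hydroxy end of the chain counts for more also stays open.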